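The compounds below may be only part of what the source reports. "The series", "measured", "known", "first", "only" and "open" are said of these compounds alone.

Among the compounds with values here, compound 2 `O=C(c1ccccc1F)N1CCC(NCCSC(c2ccc(F)cc2)c2ccc(F)cc2)CC1` gives 3.57 nM in an assay on membranes from Cortex for displacement of a labelled ligand from Sigma non-opioid intracellular receptor 1 (Cavia porcellus), read by scintillation counting, with a stated time of 120 min (a lower number here means a stronger inhibitor, a higher number a weaker inhibitor), and stands lowest of the two numbers measured so far. Compound 1 `Fc1ccc(C(SCCNC2CCN(CC3CC3)CC2)c2ccc(F)cc2)cc1` gives 269 nM in this assay. Within the data shown here, the only measured step, a 75-fold lower number from compound 1 to compound 2 (1.88 log units; beyond the scatter), concerns the substituent on the amine nitrogen in the ring, not the aryl ring of the carbonyl group. Compound 3 `O=C(c1ccc(F)cc1F)N1CCC(NCCSC(c2ccc(F)cc2)c2ccc(F)cc2)CC1` differs from compound 2 by fluoro in place of hydrogen on an aromatic carbon. Among the measured compounds shown here, no measured step bears on adding a fluoro to this ring, so no step beyond the scatter is expected. Compound 3 is estimated at 3.5 nM, with a range of 1.2 nM to 10 nM. The expected step is a 1.0-fold lower number from compound 2 to compound 3 (0.01 log units; within the scatter).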

Compound 3, inhibition constant: 20.6 nM
Compound 3: middle estimate off by 5.9-fold (0.77 log units), on the low side, outside the stated range (above it).
By their numbers in this assay, from the lowest: compound 2; then compound 3; then compound 1.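

Fluoro is not a neutral addition on this aromatic ring: placed meta to the existing fluoro group and para to the large group, it gives a 5.8-fold higher number from compound 2 to compound 3 (0.76 log units; beyond the scatter) in this assay. The (2,4-difluorophenyl)carbonyl group still retains a clear gain over cyclopropylmethyl on the ring amine nitrogen, with a 13-fold lower number from compound 1 to compound 3 (1.12 log units; beyond the scatter), so this added fluoro gives back only part of the gain from that exchange. No evidence bears on the origin of the higher number.

On these data alone, whether chloro, methoxy or nitrile on the same carbon would give a similar step remains open. So does the effect of removing the existing fluoro group from this ring.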